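Hydroxy to fluoro on the 3-substituted phenyl series

The source may hold more compounds than are shown below. What is called first, only, known or untested is meant among the compounds shown, and "the series" means these compounds.

- compound 1 `COc1ccccc1-c1ccc2ncn(-c3cc(OC)c(OC)c(OC)c3)c2c1`: 5050 nM
- compound 2 `COc1cc(-n2cnc3ccc(-c4cc(F)ccc4F)cc32)cc(OC)c1OC`: 6590 nM
- compound 3 `COc1cc(-n2cnc3ccc(-c4cccc(O)c4)cc32)cc(OC)c1OC`: 53 nM

In a functional assay on SGC-7901 cells (Homo sapiens) for antiproliferative activity, read by MTT assay, with a stated time of 72 h (on this read-out lower numbers stand for stronger inhibition and higher numbers for weaker inhibition), compound 3 gives the lowest of the three numbers, at 53 nM, and its steps to both others lie beyond the scatter. Compound 4 `COc1cc(-n2cnc3ccc(-c4cccc(F)c4)cc32)cc(OC)c1OC` has fluoro in place of hydroxy on an aromatic carbon, meta to a large group: fluoro in place of hydroxy on an aromatic carbon.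

Among the compounds with values here, no measured pair makes this exact change, so the evidence is indirect. Replacing either other aryl group with 3-hydroxyphenyl gave a large step: a 95-fold lower number from compound 1 to compound 3 (1.98 log units; beyond the scatter), and a 120-fold lower number from compound 2 to compound 3 (2.09 log units; beyond the scatter). By contrast, a 1.3-fold higher number from compound 1 to compound 2 (0.12 log units; within the scatter) shows that these two compounds do not separate. Neither compound carries hydroxy, but neither is a 3-substituted phenyl either, so compound 4 need not lose the whole of those steps. A rise beyond the scatter is expected, though probably a smaller one.

The expected step is a 13-fold higher number from compound 3 to compound 4 (1.12 log units; beyond the scatter). For compound 4 the estimated value is 700 nM, with an expected range of 120 nM to 4000 nM.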

Compound 4, half-maximal inhibitory concentration: 2490 nM
Estimate against measurement, compound 4: 3.6-fold (0.55 log units) below; low and high end bracket the measured number.
By their numbers in this assay, from the lowest: compound 3; then compound 4; then compounds 1 and 2 (each within the scatter of the next).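

In this assay, a 3-substituted phenyl is not enough to keep the low number of compound 3, since fluoro in place of hydroxy on the same carbon gives a large rise (a 47-fold higher number from compound 3 to compound 4 (1.67 log units; beyond the scatter)). Compound 4 instead stays much nearer the two compounds without hydroxy, with only modest steps from each (a 2.6-fold lower number from compound 2 to compound 4 (0.42 log units; beyond the scatter); a 2.0-fold lower number from compound 1 to compound 4 (0.31 log units; beyond the scatter)), so most of the gain in this small set appears only with 3-hydroxyphenyl. Nothing at hand gives a measured reason for the gap between hydroxy and fluoro at this position.

As far as these compounds go, whether an amine or a carboxylic acid on the same carbon would hold a number close to that of compound 3 stays open. Also open, from the compounds shown here alone, is whether hydroxy gives a similar gain elsewhere on this phenyl ring.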